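Benzamide in Place of Aryl Urea on the Shared Core

This account rests on a few compounds, and the source may have more. Where it says the series, first, only, none or still open, it means among the compounds named here.

Measured compounds: compound 1 `COc1cc(-c2nn(-c3cccc(NC(=O)Nc4cccc(C(F)(F)F)c4)c3)cc2-c2ccncc2)ccc1Cl` gives 1130 nM in a functional assay on SF-295 cells (Homo sapiens) for inhibition, read by sulforhodamine B assay, with a stated time of 48 h; on this read-out higher numbers stand for weaker inhibition of growth and lower numbers for stronger inhibition of growth; compound 2 `COc1cc(-c2nn(-c3cccc(NC(=O)c4ccc(Cl)c(C(F)(F)F)c4)c3)cc2-c2ccncc2)ccc1Cl` gives 17300 nM; compound 3 `COc1cc(-c2nn(-c3cccc(NC(=O)Nc4ccc(Cl)c(C(F)(F)F)c4)c3)cc2-c2ccncc2)ccc1Cl` gives 2540 nM.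

Compound 3 stands second highest of the three numbers, nearer to compound 1 than to compound 2. Compound 4 `COc1cc(-c2nn(-c3cccc(NC(=O)c4ccccc4)c3)cc2-c2ccncc2)ccc1Cl` differs from it by phenyl in place of (4-chloro-3-(trifluoromethyl)phenyl)amino on a carbonyl carbon. Going by the values given here, two measured steps bear on this: the urea-to-amide change gave a 15-fold higher number from compound 1 to compound 2 (1.18 log units; beyond the scatter), and the reverse amide-to-urea change gave a 6.8-fold lower number from compound 2 to compound 3 (0.83 log units; beyond the scatter). Removing chloro alone, as in a 2.2-fold higher number from compound 1 to compound 3 (0.35 log units; beyond the scatter), was a smaller effect. A clearly higher number is therefore expected for compound 4, about a 5.9-fold higher number from compound 3 to compound 4 (0.77 log units; beyond the scatter). Compound 4 is estimated at 15000 nM, within 5000 nM to 45000 nM.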

Compound 4, concentration for total growth inhibition: 2260 nM
Compound 4: middle estimate off by 6.6-fold (0.82 log units), on the high side, outside the stated range (below it).
By their numbers in this assay, from the lowest: compounds 1, 4 and 3 (each within the scatter of the next, the first and the last beyond it); then compound 2.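

In this assay the plain benzamide shows a 7.7-fold lower number from compound 2 to compound 4 (0.88 log units; beyond the scatter) in a step that removes only the chloro and trifluoromethyl groups, so an amide on this carbonyl carbon does not by itself give a high number. Replacing the urea arm with phenyl gives a 1.1-fold lower number from compound 3 to compound 4 (0.05 log units; within the scatter) and, against the other urea, a 2.0-fold higher number from compound 1 to compound 4 (0.30 log units; within the scatter) and both steps lie within the scatter. The urea nitrogen and its substituted ring are therefore not required for this level of growth inhibition among these compounds.

No outside data explain why compound 2 stands apart. Benzamides carrying only chloro, only trifluoromethyl or an amine on the phenyl ring remain open.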